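This account rests on a few compounds, and the source may have more. Where it says the series, first, only, none or still open, it means among the compounds named here.

Measured compounds:
- compound 1 `CNC(=O)c1cc(Oc2ccc(Nc3nccc(N4CCCC4)n3)cc2)ccn1`: 66.4%
- compound 2 `CNC(=O)c1cc(Oc2ccc(Nc3nccc(N4CCCCC4)n3)cc2)ccn1`: 69.8%
- compound 3 `CN(c1ccc(Oc2ncnc3ccsc23)cc1)c1nccc(N2CCc3ccccc32)n1`: 57.8%

All three values come from a functional assay on HCT-116 cells (Homo sapiens) for inhibition, read by MTT assay, with a stated time of 72 h, tested at 20 uM; a higher number here means more inhibition at the concentration tested (going by the name of the read-out), a lower number less inhibition. Compound 2 gives the largest of the three numbers; its gap to compound 1 is within the scatter, while its gap to compound 3 is beyond it, so only compound 3 is separated from compound 2 with any confidence.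

Among the compounds with values here, the one step between neighbours that differ in a single place is a number 3.4 percentage points higher from compound 1 to compound 2 (within the scatter). It concerns the saturated ring on the shared core and says nothing about the aryl ether end.

Compound 4 `c1cc(N2CCCCC2)nc(Nc2ccc(Oc3ncnc4ccsc34)cc2)n1` is not yet measured. It differs from compound 2 as follows: a group of 9 heavy atoms (6 carbon, 2 nitrogen, 1 sulfur; one five-membered aromatic ring with 1 hetero atom, one six-membered aromatic ring with 2 hetero atoms) in place of a group of 10 heavy atoms (7 carbon, 2 nitrogen, 1 oxygen; one six-membered aromatic ring with 1 hetero atom), on an oxygen on an aromatic ring

Within the data shown here, no measured step isolates this exchange. Compound 3 carries the same entering group at the ether oxygen but differs from compound 2 in more than one place, so its value can only be read as a loose indication. With compound 3 at 57.8% and compound 2 at 69.8%, the expectation for compound 4 is a modest drop, a number 7.8 percentage points lower from compound 2 to compound 4 (within the scatter), at the edge of the scatter. Compound 4 is estimated at 62%, with a range of 48% to 76%.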

Compound 4, a percentage reported as inhibition, at one concentration (the size of the read-out at that concentration, not a potency): 61.5%
Compound 4: the middle estimate sits 0.5 percentage points above what was measured; the measured number falls inside the stated range.
By their numbers in this assay, from the lowest: compounds 3, 4, 1 and 2 (each within the scatter of the next, the first and the last beyond it).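

In this assay, within the data shown here, the exchange on the oxygen on an aromatic ring gives a number 8.3 percentage points lower from compound 2 to compound 4 (within the scatter), the first direct reading at this position, since the earlier step concerned only the saturated ring on the shared core. The 2-(methylcarbamoyl)pyridin-4-yl group can thus be replaced by a fused group with a five-membered and a six-membered aromatic ring, with 0 hydrogen-bond donors, without a change beyond the scatter, so neither that group's amide nor its hydrogen-bond donor is shown to be needed for inhibition at the single concentration tested. No measured data on these compounds explain the result.

Going by these compounds, whether the pyrrolidin-1-yl and piperidin-1-yl rings also read alike with the fused group on the oxygen remains open, as the step between them stands only with the 2-(methylcarbamoyl)pyridin-4-yl group in place. Also open is how a plain phenyl group, or a pyridin-4-yl group bearing a carboxylic acid instead of the methylcarbamoyl group, would read at this oxygen, and single-concentration numbers of this kind give no potency for any of these compounds.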